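The source may hold more compounds than are shown below. What is called first, only, known or untested is meant among the compounds shown, and "the series" means these compounds.

Working notes on the series. Compound 1 `N#Cc1ccc2[nH]c(Cc3ccc(Oc4ccccc4)cc3)nc2c1` gives 3400 nM in an assay on membranes from brain for binding affinity to Adrenergic receptor alpha-1 (Rattus norvegicus); on this read-out lower numbers stand for stronger inhibition and higher numbers for weaker inhibition. Compound 2 `CS(=O)(=O)Nc1ccc2[nH]c(Cc3ccc(Oc4ccccc4)cc3)nc2c1` gives 4000 nM, and compound 3 `O=S(=O)(Nc1ccc2[nH]c(Cc3ccc(Oc4ccccc4)cc3)nc2c1)c1ccccc1` gives 14000 nM. Compound 3 has the highest number of the three: the gap is a 3.5-fold higher number from compound 2 to compound 3 (0.54 log units; beyond the scatter) and a 4.1-fold higher number from compound 1 to compound 3 (0.61 log units; beyond the scatter), both beyond the scatter, while a 1.2-fold higher number from compound 1 to compound 2 (0.07 log units; within the scatter) stays within it.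

Compound 4 `CC(=O)Nc1ccc2[nH]c(Cc3ccc(Oc4ccccc4)cc3)nc2c1` has not yet been measured. The change from compound 3 is acetyl in place of phenylsulfonyl on a nitrogen on an aromatic ring. Among the measured compounds shown here, the step that bears on this is a 3.5-fold higher number from compound 2 to compound 3 (0.54 log units; beyond the scatter), where phenyl on the sulfonyl sulfur carried a modest rise in the number; the move to acetyl removes that phenyl ring again and shortens the group to three heavy atoms, but also exchanges sulfonyl for carbonyl, for which no measured pair exists. Compound 4 is therefore expected to fall back towards the number of compound 2, giving an estimated step of a 3.5-fold lower number from compound 3 to compound 4 (0.54 log units; beyond the scatter). The estimate for compound 4 is 4000 nM, with a range from 1500 nM to 11000 nM.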

Compound 4, half-maximal inhibitory concentration: 20000 nM
Estimate against measurement, compound 4: 5.0-fold (0.70 log units) below, outside the stated range (above it).
By their numbers in this assay, from the lowest: compounds 1 and 2 (each within the scatter of the next); then compounds 3 and 4 (each within the scatter of the next).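

Removing the phenyl ring from the nitrogen on an aromatic ring does not by itself restore the lower number: a 1.4-fold higher number from compound 3 to compound 4 (0.15 log units; within the scatter) stays within the scatter in this assay, so phenylsulfonyl with 9 heavy atoms and acetyl with 3 cannot be told apart here. Group size alone therefore does not order the series, and compound 2 goes against any such reading: a 5.0-fold higher number from compound 2 to compound 4 (0.70 log units; beyond the scatter) lies beyond the scatter for acetyl in place of methylsulfonyl. The acetamido group also separates from the nitrile, with a 5.9-fold higher number from compound 1 to compound 4 (0.77 log units; beyond the scatter) beyond the scatter, which places compounds 3 and 4 apart from compounds 1 and 2.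

No measurement shown gives a reason for this split. Still open, as far as these compounds go, is how a free amine or a longer acyl chain such as butanoyl on that nitrogen would read.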